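The source may hold more compounds than are shown below. What is called first, only, known or untested is meant among the compounds shown, and "the series" means these compounds.

Compound 1 `CCC1CCCCN1c1nc(C)nc2c(-c3c(C)cc(OC)cc3OC)c(C)nn12` gives 3.26 nM in an assay on cell membranes for displacement of a labelled ligand from corticotropin-releasing factor receptor 1 (Rattus norvegicus); on this read-out higher numbers stand for weaker inhibition and lower numbers for stronger inhibition.
Compound 2 `CCN(CC)c1nc(C)nc2c(-c3c(C)cc(OC)cc3OC)c(C)nn12` gives 1.2 nM.
Compound 3 `C=CCN(CC=C)c1nc(C)nc2c(-c3c(C)cc(OC)cc3OC)c(C)nn12` gives 1 nM.

All three share one core and differ only in the amine on the aromatic carbon. Compound 3 stands at the low end of these numbers: against compound 1 the step of a 3.3-fold lower number from compound 1 to compound 3 (0.51 log units; beyond the scatter) lies beyond the scatter, whereas against compound 2 the step of a 1.2-fold lower number from compound 2 to compound 3 (0.08 log units; within the scatter) lies within it, so those two cannot be told apart. Compound 4 `COc1cc(C)c(-c2c(C)nn3c(NC4CCC4)nc(C)nc23)c(OC)c1` carries the change (cyclobutylamino in place of diallylamino on an aromatic carbon). Going by the values given here, the steps that bear on this are the two replacements of the 2-ethylpiperidin-1-yl group, a 2.7-fold lower number from compound 1 to compound 2 (0.43 log units; beyond the scatter) and a 3.3-fold lower number from compound 1 to compound 3 (0.51 log units; beyond the scatter), both modest, and the swap between the two acyclic groups, a 1.2-fold lower number from compound 2 to compound 3 (0.08 log units; within the scatter), within the scatter. Among the compounds with values here, none of them brings in a hydrogen-bond donor or a four-membered ring, so the new change has no direct precedent here. The three numbers span a narrow band, and a step of at most modest size, most likely a small rise in the number, is expected. For compound 4 the expected step is a 3.0-fold higher number from compound 3 to compound 4 (0.48 log units; beyond the scatter). Compound 4 is estimated at 3 nM, with a range from 1 nM to 10 nM.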

Compound 4, half-maximal inhibitory concentration: 17.4 nM
For compound 4 the middle estimate is 5.8-fold (0.76 log units) below the measured one, outside the stated range (above it).
By their numbers in this assay, from the lowest: compounds 3 and 2 (each within the scatter of the next); then compound 1; then compound 4.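

The amine on this carbon, which sits between two ring nitrogen atoms, matters more than the first three compounds showed: cyclobutylamino gives a 17-fold higher number from compound 3 to compound 4 (1.24 log units; beyond the scatter) and a 15-fold higher number from compound 2 to compound 4 (1.16 log units; beyond the scatter), both large, whereas the earlier swaps were modest at most. It also falls behind the 2-ethylpiperidin-1-yl group, with a 5.3-fold higher number from compound 1 to compound 4 (0.73 log units; beyond the scatter), so among these four amines, the only one with a hydrogen-bond donor and a four-membered ring has the highest number. No measurement available here accounts for this rise.

Still open, going by these compounds, is whether the rise goes with the hydrogen on the nitrogen or with the four-membered ring. A methyl(cyclobutyl)amino group keeps the ring without that hydrogen, and an open-chain butylamino group keeps the hydrogen without the ring, so the two would separate these features.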